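From compound 2 to compound 3: one substituent enlarged

This account rests on a few compounds, and the source may have more. Where it says the series, first, only, none or still open, it means among the compounds named here.

Of the compounds shown here, two have numbers so far in a physicochemical assay for solubility, in phosphate buffer, with a stated time of 2 h; a lower number here means a less soluble compound, a higher number a more soluble compound. Compound 1 `CCCCc1ccc(-c2nc(C)c(/C(C)=N/NC(=N)N)s2)cc1` gives 62500 nM and compound 2 `Cc1nc(-c2ccc(-c3ccccc3)cc2)sc1-c1nnc(NN)o1` gives 77000 nM, which places compound 2 within the scatter of compound 1, with no order between them. Compound 3 `Cc1nc(-c2ccc(-c3ccccc3)cc2)sc1-c1nnc(NC(=N)N2CCN(C)CC2)o1` differs from compound 2 in one place: a group of 9 heavy atoms (6 carbon, 3 nitrogen; one six-membered non-aromatic ring with 2 hetero atoms) in place of one nitrogen atom, on a nitrogen on an aromatic ring. The change sits on a nitrogen on an aromatic ring and brings in one six-membered non-aromatic ring with 2 hetero atoms. For the measured compounds named here, no measured step covers this change, so no shift beyond the scatter is expected in this assay, in either direction. The expected change is a 1.1-fold lower number from compound 2 to compound 3 (0.04 log units; within the scatter). Compound 3 is estimated at 70000 nM, with an expected range of 20000 nM to 250000 nM.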

Compound 3, solubility: 104000 nM
Compound 3: the middle estimate sits 1.5-fold (0.17 log units) below what was measured; the range from low to high includes it.
By their numbers in this assay, from the lowest: compounds 1, 2 and 3 (each within the scatter of the next).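

In this assay, for the compounds shown here, the first measured step at this position, a nitrogen on an aromatic ring, puts the amino group's replacement by a much larger group carrying a six-membered non-aromatic ring at a 1.4-fold higher number from compound 2 to compound 3 (0.13 log units; within the scatter). On this single pair, the position accepts that enlargement with no shift beyond the scatter. No measurement available bears on what lies behind this step.

As far as these compounds go, whether a morpholine ring or a longer chain in the same place would also stay within the scatter remains open. Equally open, from the compounds shown here alone, is whether a carboxylic acid there would shift the number beyond it.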